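A few compounds are considered here, and "the series" means these few. Any claim that something is new, unique, unknown or untested is made for them only; others in the source may bear on it.

The measured compounds:
Compound 1, `CC(C)[C@H](NC(=O)COc1cccc2ccccc12)C(=O)N[C@@H](CC(=O)O)C(=O)CSc1ncc[nH]1`. In a functional assay on Jurkat cells (Homo sapiens) for inhibition (a lower number here means a stronger inhibitor, a higher number a weaker inhibitor), compound 1 gives > 200000 nM, a limit of the assay and not a number.
Compound 2, `CC(C)[C@H](NC(=O)COc1cccc2ccccc12)C(=O)N[C@@H](CC(=O)O)C(=O)CSc1nc[nH]n1`. Compound 2 gives > 200000 nM, also a limit.
Compound 3, `CC(C)[C@H](NC(=O)COc1cccc2ccccc12)C(=O)N[C@@H](CC(=O)O)C(=O)CSc1nncn1C`. Compound 3 gives > 200000 nM, again a limit.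

Compound 1 therefore stands at the limit of > 200000 nM in this assay, at which 3 of the 3 values shown sit. The change to compound 4, `CC(C)[C@H](NC(=O)COc1cccc2ccccc12)C(=O)N[C@@H](CC(=O)O)C(=O)CSc1nc2ccccc2o1`, is 1,3-benzoxazol-2-yl in place of 1H-imidazol-2-yl on a sulfur. The two steps that alter the same sulfur-bound ring, a step that the two limits leave unreadable from compound 1 to compound 2 and a step that the two limits leave unreadable from compound 1 to compound 3, both run between limits and reveal neither size nor direction. Among the measured compounds shown here, no measured step brings in a 1,3-benzoxazol-2-yl group. With every value at a limit, nothing supports a move in either direction, so the step of a number no higher from compound 1 to compound 4 (the limit leaves the size open) is an expectation only. Compound 4 is thus expected at 200000 nM, within 40000 nM and 1000000 nM.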

Compound 4, half-maximal inhibitory concentration: > 200000 nM
Compound 4 gave a limit, no number; the forecaster's own chance of this, stated with the estimate: 75%; the middle value sits exactly at the limit.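

Among the compounds shown here, compound 4, like compound 1, compound 2 and compound 3, gives only a limit and not a number, so no step to compound 4 can be read. As far as these compounds go, whether these sulfur-bound rings differ at all in this assay stays open.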